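Series notes: bromo to chloro on the pendant phenyl

This account rests on a few compounds, and the source may have more. Where it says the series, first, only, none or still open, it means among the compounds named here.

Three compounds share one core. Compound 1 `OCC(O)Cn1nc2c(Br)c(Br)c(Br)c(Br)c2n1` gives 8% in a functional assay on MCF7 cells (Homo sapiens) for antiproliferative activity, read by MTT assay, with a stated time of 48 h, tested at 100 uM; a higher number here means a weaker effect of the compound at the concentration tested, a lower number a stronger effect. Among the compounds with values here, compound 3 `C[C@@H](O)CCn1nc2c(Br)c(Br)c(Br)c(Br)c2n1` gives 0%, and the only one-place step measured, a number 8 percentage points lower from compound 1 to compound 3 (within the scatter), stays within the scatter. Compound 2 `OC(CCn1nc2c(Br)c(Br)c(Br)c(Br)c2n1)c1ccc(Br)cc1` gives 0%; it stands at the same digits as compound 3, and compound 1 lies within the scatter of both. Compound 4 `OC(CCn1nc2c(Br)c(Br)c(Br)c(Br)c2n1)c1ccc(Cl)cc1` differs from compound 2 by chloro in place of bromo on an aromatic carbon. Within the data shown here, no measured step covers a halogen swap on that ring; the one step available, from compound 1 to compound 3, did not move the read-out beyond the scatter, and all three values sit close together at the low end of the read-out. Compound 4 is therefore expected to show no change beyond the scatter, a number 2 percentage points higher from compound 2 to compound 4 (within the scatter). The estimate for compound 4 is 2%, within 0% to 12%.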

Compound 4, a percentage reported as activity, at one concentration (the size of the read-out at that concentration, not a potency): 0%
Compound 4: middle estimate off by 2 percentage points, on the high side, and the stated range covers the measured number.
By their numbers in this assay, from the lowest: compounds 2, 3, 4 and 1 (each within the scatter of the next).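

In this assay, within the data shown here, the swap from 4-bromophenyl to 4-chlorophenyl gives the first reading on a halogen change on this ring, para to a large group, with no change at the digits printed from compound 2 to compound 4 (within the scatter) as its step. At this position, chloro can stand in place of bromo without moving the read-out beyond the scatter, although both compounds sit at the low end of the read-out. No evidence available here accounts for this result.

Open, as far as these compounds go, is whether an amine or a carboxylic acid in place of the halogen, or a longer chain on the shared core, would move the read-out beyond the scatter.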